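Swapping Bromo for Methoxycarbonyl on the Amide Ring

The source may hold more compounds than are shown below. What is called first, only, known or untested is meant among the compounds shown, and "the series" means these compounds.

Three measured compounds share one core and differ in a single group on the outer six-membered ring. Compound 1 `COc1cc2oc(-c3cccc(NC(=O)c4ccccc4)c3)cc(=O)c2c(OC)c1OC` carries hydrogen there, compound 2 `COc1cc2oc(-c3cccc(NC(=O)c4ccc(Br)cc4)c3)cc(=O)c2c(OC)c1OC` carries bromo, and compound 3 `COc1cc2oc(-c3cccc(NC(=O)c4ccc([N+](=O)[O-])cc4)c3)cc(=O)c2c(OC)c1OC` carries nitro. In a functional assay on MCF7 cells (Homo sapiens) for inhibition, read by MTT assay (on this read-out lower numbers stand for stronger inhibition of growth and higher numbers for weaker inhibition of growth), compound 1 gives 12100 nM, compound 2 gives 9650 nM, and compound 3 gives 20100 nM. Compound 2 has the lowest number of the three, though its gap to compound 1, a 1.3-fold lower number from compound 1 to compound 2 (0.10 log units; within the scatter), lies within the scatter, while a 2.1-fold higher number from compound 2 to compound 3 (0.32 log units; beyond the scatter) is a modest step beyond it. Compound 4 `COC(=O)c1ccc(C(=O)Nc2cccc(-c3cc(=O)c4c(OC)c(OC)c(OC)cc4o3)c2)cc1` is reached from compound 2 by methoxycarbonyl in place of bromo on an aromatic carbon. Among the measured compounds shown here, the steps that bear on this change are a 1.3-fold lower number from compound 1 to compound 2 (0.10 log units; within the scatter), a 1.7-fold higher number from compound 1 to compound 3 (0.22 log units; within the scatter) and a 2.1-fold higher number from compound 2 to compound 3 (0.32 log units; beyond the scatter): every swap at this position moved the number little, and the only step beyond the scatter raised it. A small rise, if any, is therefore expected, a 1.5-fold higher number from compound 2 to compound 4 (0.16 log units; within the scatter). Compound 4 is estimated at 14000 nM, with a range from 7000 nM to 28000 nM.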

Compound 4, concentration for 50% growth inhibition: 30300 nM
Beside the measured number, compound 4's estimate is 2.2-fold (0.34 log units) below it; the measured number lies above the stated range.
By their numbers in this assay, from the lowest: compounds 2, 1, 3 and 4 (each within the scatter of the next, the first and the last beyond it).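

In this assay, this position turns out to move the number more than the earlier swaps suggested: a 3.1-fold higher number from compound 2 to compound 4 (0.50 log units; beyond the scatter) is the largest step in the series, and a 2.5-fold higher number from compound 1 to compound 4 (0.40 log units; beyond the scatter) puts methoxycarbonyl beyond the scatter from plain hydrogen, which neither bromo nor nitro reached. Yet a 1.5-fold higher number from compound 3 to compound 4 (0.18 log units; within the scatter) stays within the scatter, so methoxycarbonyl and nitro cannot be told apart on this read-out, and the clear gap lies only between methoxycarbonyl and the hydrogen and bromo compounds. No measured evidence is available to explain this rise.

The compounds shown leave open whether a carboxylic acid or an amine at this same place would raise the number further or bring it back down. They also leave open whether an ester with a longer chain would behave like methoxycarbonyl.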